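Vinyl to pent-1-en-1-yl: an estimate for compound 4

This account rests on a few compounds, and the source may have more. Where it says the series, first, only, none or still open, it means among the compounds named here.

Compound 1 `CCC/C=C/C(=O)Nc1cccc(Oc2nc(Nc3cccc(OC)c3)nc3c2CSCC3)c1` gives 32000 nM
Compound 2 `C=CC(=O)Nc1cccc(Oc2nc(Nc3cccc(C#N)c3)nc3c2CSCC3)c1` gives 21700 nM
Compound 3 `C=CC(=O)Nc1cccc(Oc2nc(Nc3ccc(OC)cc3)nc3c2CSCC3)c1` gives 11700 nM

In a functional assay on MCF7 cells (Homo sapiens) for antiproliferative activity, read by MTT assay, with a stated time of 72 h (on this read-out lower numbers stand for stronger inhibition and higher numbers for weaker inhibition), compound 3 (11700 nM) lies within the scatter of compound 2, while compound 1 gives a higher number than compound 3. Compound 4 `CCC/C=C/C(=O)Nc1cccc(Oc2nc(Nc3ccc(OC)cc3)nc3c2CSCC3)c1` differs from compound 3 by pent-1-en-1-yl in place of vinyl on a carbonyl carbon and in nothing else. Among the compounds with values here, the one measured step (a 1.9-fold lower number from compound 2 to compound 3 (0.27 log units; within the scatter)) concerns the group on the nitrogen, so no measured pair isolates this change. Only compound 1 (32000 nM) already carries pent-1-en-1-yl, and it also has a different group on that nitrogen. A modest rise is therefore expected (a 1.7-fold higher number from compound 3 to compound 4 (0.23 log units; within the scatter)) in this assay with wide uncertainty. For compound 4 the estimated value is 20000 nM with an expected range from 9000 nM to 45000 nM.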

Compound 4, half-maximal inhibitory concentration: > 50000 nM
Compound 4 gave a limit, no number; the forecaster's own chance of this, stated with the estimate: 15%; middle value at least 2.5-fold (0.39 log units) away from the limit.
By their numbers in this assay, from the lowest: compounds 3, 2 and 1 (each within the scatter of the next, the first and the last beyond it). At a limit, above all of these: compound 4.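

In this assay compound 4 gives a limit of the assay, > 50000 nM, and not a number. Within the data shown here, with 4-methoxyphenyl held constant, pent-1-en-1-yl in place of vinyl on a carbonyl carbon gives an at least 4.2-fold higher number from compound 3 to compound 4 (0.63 log units; beyond the scatter), the first read of this change on its own. With pent-1-en-1-yl held constant, 4-methoxyphenyl in place of 3-methoxyphenyl gives an at least 1.5-fold higher number from compound 1 to compound 4 (0.19 log units; that floor lies within the scatter), so that pair sets no order.

The compounds shown leave open how a chain of intermediate length, such as prop-1-en-1-yl, or a chain carrying an amine would read in this assay. Also open, from the compounds shown here alone, is how far the true value of compound 4 lies past its limit.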